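Swapping 1H-pyrazol-1-yl for 2-hydroxyphenyl in compound 2

The source may report more compounds than this note shows. Statements on the series, on what has been measured and on what is new or still open speak of the compounds shown alone.

Measured compounds:
compound 1 `NC1CCC(Nc2nc(NCc3ccc(Br)cc3)c3ncn(C4CCCC4)c3n2)CC1`: 995 nM
compound 2 `NC1CCC(Nc2nc(NCc3ccc(-n4cccn4)cc3)c3ncn(C4CCCC4)c3n2)CC1`: 103 nM

In a functional assay on HOS cells (Homo sapiens) for inhibition, with a stated time of 72 h (on this read-out lower numbers stand for stronger inhibition and higher numbers for weaker inhibition), compound 2 has the lower of the two numbers, 103 nM. Compound 3 `NC1CCC(Nc2nc(NCc3ccc(-c4ccccc4O)cc3)c3ncn(C4CCCC4)c3n2)CC1` carries 2-hydroxyphenyl in place of 1H-pyrazol-1-yl on an aromatic carbon. For the measured compounds named here, only one measured step bears on this place: a 9.7-fold lower number from compound 1 to compound 2 (0.98 log units; beyond the scatter). Going by the values given here, it shows that a swap here can move the number clearly, but no measurement yet compares these two groups. No direction can be argued in this assay, so no step beyond the scatter is expected, though with real uncertainty. The estimated change is a 1.1-fold lower number from compound 2 to compound 3 (0.06 log units; within the scatter). For compound 3 the expected value is 90 nM, within an estimated range of 30 nM to 300 nM.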

Compound 3, half-maximal inhibitory concentration: 1160 nM
Compound 3: middle estimate off by 13-fold (1.11 log units), on the low side; measured number outside the range, above it.
By their numbers in this assay, from the lowest: compound 2; then compounds 1 and 3 (each within the scatter of the next).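

In this assay, the gain brought by 1H-pyrazol-1-yl at this position is lost when 2-hydroxyphenyl takes its place, with an 11-fold higher number from compound 2 to compound 3 (1.05 log units; beyond the scatter). Against the original bromo, 2-hydroxyphenyl gives a 1.2-fold higher number from compound 1 to compound 3 (0.07 log units; within the scatter), so the improvement does not extend to every aromatic ring placed here. No measurement is available to explain this difference.

The compounds shown leave open whether the hydroxy group or the six-membered carbon ring separates compound 3 from compound 2. A plain phenyl group here would help to tell those two apart.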